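The source may hold more compounds than are shown below. What is called first, only, known or untested is meant among the compounds shown, and "the series" means these compounds.

Compound 1 `Cc1cc(-c2ccc(C#N)cc2)cc(C)c1Nc1ccnc(Nc2ccc(C#N)cc2)n1` gives 2080 nM in an ADME assay on MT4 cells (Homo sapiens) for cytotoxicity, read by MTT assay, with a stated time of 4 days; on this read-out higher numbers stand for lower toxicity in this test and lower numbers for higher toxicity in this test. Compound 2 `COc1ccc(-c2cc(C)c(Nc3ccnc(Nc4ccc(C#N)cc4)n3)c(C)c2)cc1` gives 2890 nM in this assay.

Within the data shown here, compound 1 stands at the edge of this small set, with compound 2 as its only neighbour, and the two are not separated in this assay, as the step of a 1.4-fold higher number from compound 1 to compound 2 (0.14 log units; within the scatter) shows. Compound 3 `COc1ccccc1-c1cc(C)c(Nc2ccnc(Nc3ccc(C#N)cc3)n2)c(C)c1` differs from compound 1 by 2-methoxyphenyl in place of 4-cyanophenyl on an aromatic carbon. Among the measured compounds shown here, the only measured step that bears on this change is a 1.4-fold higher number from compound 1 to compound 2 (0.14 log units; within the scatter), which also swaps a cyano for a methoxy on that ring and stays within the scatter. Compound 3 is therefore expected to show a step of a 1.2-fold higher number from compound 1 to compound 3 (0.08 log units; within the scatter) in this assay, that is, none beyond the scatter. Compound 3 is estimated at 2500 nM, with a range from 1200 nM to 5200 nM.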

Compound 3, half-maximal cytotoxic concentration: 940 nM
For compound 3 the middle estimate is 2.7-fold (0.42 log units) above the measured one; the measured number lies below the stated range.
By their numbers in this assay, from the lowest: compound 3; then compounds 1 and 2 (each within the scatter of the next).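

In this assay this position now proves sensitive to the group it carries: 2-methoxyphenyl in place of 4-cyanophenyl gives a 2.2-fold lower number from compound 1 to compound 3 (0.34 log units; beyond the scatter), and 2-methoxyphenyl in place of 4-methoxyphenyl gives a 3.1-fold lower number from compound 2 to compound 3 (0.49 log units; beyond the scatter). Among these three compounds, a methoxy-bearing ring alone does not set the number, since only the 2-methoxyphenyl of compound 3 stands apart, on the side of higher toxicity in this test. No measurement offered here explains this shift.

From the compounds shown here alone, whether an amine or a carboxylic acid on this ring would move the number further, and in which direction, remains open. So does whether a nitrile placed where compound 3 carries its methoxy would give a similar step.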